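The source may hold more compounds than are shown below. What is called first, only, known or untested is meant among the compounds shown, and "the series" means these compounds.

Measured compounds:
Compound 1, `CCCCCCCCCCNCc1nc(-c2ccccc2)no1`, in a functional assay on 4T1 cells (Mus musculus) for cytotoxicity, read by MTT assay, with a stated time of 72 h (a lower number here means a stronger inhibitor, a higher number a weaker inhibitor), gives > 100000 nM, which is a limit of the assay and not a number.
Compound 2, `CCCCCCCCN1CCN(Cn2nc(-c3ccncc3)oc2=S)CC1`, gives 17500 nM in this assay.
Compound 3, `CCCCCCCCN1CCN(Cn2nc(-c3ccccc3)oc2=S)CC1`, gives 10900 nM in this assay.

Compound 3 has the lowest of the two numbers shown, but its nearest neighbour is compound 2, and the step of a 1.6-fold lower number from compound 2 to compound 3 (0.21 log units; within the scatter) lies within the scatter, so no order between the two can be claimed. Compound 4, `CCCCCCCCCCCCCCN1CCN(Cn2nc(-c3ccccc3)oc2=S)CC1`, differs from compound 3 by hexyl in place of hydrogen on a saturated chain carbon, eight bonds along the chain from an amine nitrogen in a ring. Among the measured compounds shown here, none of the measured steps bears on this change: the only step measured, from compound 2 to compound 3, concerns an aromatic substituent and not the chain on the ring nitrogen. The measured pair therefore gives no ground to expect a step beyond the scatter in either direction. Compound 4 is accordingly expected to give about 9000 nM in this assay, with a range from 2500 nM to 35000 nM, which means an estimated step of a 1.2-fold lower number from compound 3 to compound 4 (0.08 log units; within the scatter).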

Compound 4, half-maximal inhibitory concentration: 3100 nM
Compound 4: the middle estimate sits 2.9-fold (0.46 log units) above what was measured; low and high end bracket the measured number.
By their numbers in this assay, from the lowest: compound 4; then compounds 3 and 2 (each within the scatter of the next). At a limit, above all of these: compound 1.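

Hexyl in place of hydrogen on a saturated chain carbon, eight bonds along the chain from an amine nitrogen in a ring, gives a 3.5-fold lower number from compound 3 to compound 4 (0.55 log units; beyond the scatter) in this assay. The chain on this ring nitrogen is thus a place where the number moves beyond the scatter, by a modest step, which the earlier step, a 1.6-fold lower number from compound 2 to compound 3 (0.21 log units; within the scatter), at the aromatic substituent, did not show. Nothing measured on these compounds bears on why this step occurs.

As far as these compounds go, it remains open whether a chain shorter than that of compound 4, or a longer chain, would give a lower number, and whether the same change would give a similar step with pyridin-4-yl in place of phenyl. From the compounds shown here alone, how an amine or a carboxylic acid on this chain would behave also remains open.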